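The source may report more compounds than this note shows. Statements on the series, on what has been measured and on what is new or still open speak of the compounds shown alone.

For the measured compounds named here, in an ADME assay on KB cells (Homo sapiens) for cytotoxicity, read by MTT assay, with a stated time of 72 h (a lower number here means a stronger inhibitor, a higher number a weaker inhibitor), compound 3 (`COc1ccc(C2=C(c3cc(OC)c(OC)c(OC)c3)C(=O)C(O)C2)cc1Cl`) gives 2.5 ug/mL, the lowest of the three numbers measured so far. Compound 1 (`COc1ccc(C2=C(c3cc(OC)c(OC)c(OC)c3)C(=O)C(OC(C)=O)C2)cc1`) gives 72 ug/mL and compound 2 (`COc1ccc(C2=C(c3cc(OC)c(OC)c(OC)c3)C(=O)C(OC(C)=O)C2)cc1F`) gives 33 ug/mL. Both carry acetoxy where compound 3 carries hydroxy.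

Compound 4 (`COc1ccc(C2=C(c3cc(OC)c(OC)c(OC)c3)C(=O)C(OC(C)=O)C2)cc1Cl`) is compound 3 with hydroxy changed to acetoxy: acetyl in place of hydrogen on an oxygen on a saturated carbon. This is acetyl in place of hydrogen on an oxygen on a saturated carbon.

Going by the values given here, no measured step isolates this change. Among the compounds with values here, the only single-place step, a 2.2-fold lower number from compound 1 to compound 2 (0.34 log units; beyond the scatter), is modest and concerns fluoro in place of hydrogen on an aromatic carbon. Compound 3 differs from compound 1 and compound 2 in two places, so its gap to them cannot be assigned to hydroxy alone. Even so, the only acetoxy compounds measured, compound 1 at 72 ug/mL and compound 2 at 33 ug/mL, both stand well above it.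

A large upward move in this assay is expected, with an estimated 10-fold higher number from compound 3 to compound 4 (1.00 log units; beyond the scatter). For compound 4 the expected value is 25 ug/mL, with an estimated range of 8 ug/mL to 70 ug/mL.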

Compound 4, half-maximal inhibitory concentration: 64 ug/mL
Compound 4: the middle estimate sits 2.6-fold (0.41 log units) below what was measured, and the stated range covers the measured number.
By their numbers in this assay, from the lowest: compound 3; then compounds 2, 4 and 1 (each within the scatter of the next, the first and the last beyond it).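

In this assay the change from hydroxy to acetoxy now has a step of its own, a 26-fold higher number from compound 3 to compound 4 (1.41 log units; beyond the scatter), so the large gap that compounds 1 and 2 could only suggest is tied to this oxygen on a saturated carbon. With acetoxy in place, the aromatic substituent adds little: a 1.9-fold higher number from compound 2 to compound 4 (0.29 log units; within the scatter) and a 1.1-fold lower number from compound 1 to compound 4 (0.05 log units; within the scatter) both lie within the scatter, although a 2.2-fold lower number from compound 1 to compound 2 (0.34 log units; beyond the scatter) lies just beyond it. No measured data on these compounds offer an explanation for the step.

From the compounds shown here alone, it remains open whether hydroxy gives a similarly low number with hydrogen or fluoro on the aromatic carbon in place of chloro. Going by these compounds, it is also open whether a methyl ether, a longer acyl chain or an amine at this position would read like hydroxy or like acetoxy.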